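A few compounds are considered here, and "the series" means these few. Any claim that something is new, unique, unknown or untested is made for them only; others in the source may bear on it.

Compound 1 `COc1cc(/C=C/C(=O)c2cccc(NC(=O)c3c(Cl)cccc3Cl)c2)ccc1O`: 88%
Compound 2 `COc1cc(/C=C/C(=O)c2cccc(NC(=O)c3cc(Cl)cc(Cl)c3)c2)ccc1O`: 51%
Compound 3 `COc1cc(/C=C/C(=O)c2cccc(NC(=O)c3ccc(Cl)cc3)c2)ccc1O`: 42%

In a functional assay on HUVEC cells (Homo sapiens) for inhibition, tested at 5 ug/mL (on this read-out lower numbers stand for a weaker effect and higher numbers for a stronger effect at the one concentration tested), compound 3 gives 42% and sits at the low end of the three numbers, with compound 2 nearest, separated by a number 9 percentage points lower from compound 2 to compound 3 (within the scatter), and compound 1 furthest, separated by a number 46 percentage points lower from compound 1 to compound 3 (beyond the scatter). Compound 4 `COc1cc(/C=C/C(=O)c2cccc(NC(=O)c3ccco3)c2)ccc1O` differs from compound 3 in one place: furan-2-yl in place of 4-chlorophenyl on a carbonyl carbon. Going by the values given here, no measured step brings in a five-membered aromatic ring with one hetero atom on this carbonyl carbon. The steps that alter this group, a number 37 percentage points lower from compound 1 to compound 2 (beyond the scatter) and a number 46 percentage points lower from compound 1 to compound 3 (beyond the scatter), were large, whereas a number 9 percentage points lower from compound 2 to compound 3 (within the scatter) was not. Lacking a closer precedent, the step of a number 4 percentage points lower from compound 3 to compound 4 (within the scatter) is expected to remain within the scatter. Compound 4 is therefore estimated at 38%, ranging from 15% to 60%.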

Compound 4, a percentage reported as inhibition, at one concentration (the size of the read-out at that concentration, not a potency): 82%
The estimate for compound 4 lay 44 percentage points below the measured number, outside the stated range (above it).
By their numbers in this assay, from the lowest: compounds 3 and 2 (each within the scatter of the next); then compounds 4 and 1 (each within the scatter of the next).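

In this assay, furan-2-yl on this carbonyl carbon gives a number 40 percentage points higher from compound 3 to compound 4 (beyond the scatter) and a number 31 percentage points higher from compound 2 to compound 4 (beyond the scatter), so among these four compounds a high number does not require a chlorinated phenyl ring. The step of a number 6 percentage points lower from compound 1 to compound 4 (within the scatter) leaves furan-2-yl and 2,6-dichlorophenyl indistinguishable, although they differ in ring size and in their hetero atom or chlorine atoms. No measurement offered here accounts for this result. The compounds shown leave open whether the furan oxygen or the five-membered ring goes with the high number; thiophen-2-yl on this carbonyl carbon would bear on that.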